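The source may hold more compounds than are shown below. What is called first, only, known or untested is meant among the compounds shown, and "the series" means these compounds.

Compound 1 `O=S(=O)(NCCCNCc1ccc(Br)cc1)c1cc(C(F)(F)F)cc(C(F)(F)F)c1` and compound 2 `O=S(=O)(NCCCNCc1cccc(Cl)c1)c1cc(C(F)(F)F)cc(C(F)(F)F)c1` share the same core and differ only in the aromatic ring joined through a saturated chain carbon to an amine nitrogen. In a functional assay on BXPC-3 cells (Homo sapiens) for inhibition, read by MTT assay, with a stated time of 72 h (a higher number here means a weaker inhibitor of growth, a lower number a stronger inhibitor of growth), compound 1 gives 1500 nM. In this assay, for the measured compounds named here, compound 2 gives 3800 nM, the highest of the two numbers measured so far, and the step of a 2.5-fold higher number from compound 1 to compound 2 (0.40 log units; beyond the scatter) is modest though beyond the scatter. Compound 3 `COc1cccc(CNCCCNS(=O)(=O)c2cc(C(F)(F)F)cc(C(F)(F)F)c2)c1` has not yet been measured in this assay. The change from compound 2 to compound 3 is methoxy in place of chloro on an aromatic carbon. Going by the values given here, only one measured step exists, and it swapped one halogen-bearing ring for another, so it says little about putting methoxy in place of chloro; it does show that alterations on this ring have moved the numbers only modestly. No direction can be read from that. Compound 3 is therefore expected to show a step of a 1.1-fold lower number from compound 2 to compound 3 (0.04 log units; within the scatter), one that may well stay within the scatter. Compound 3 is estimated at 3500 nM, with a range from 1200 nM to 10000 nM.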

Compound 3, concentration for 50% growth inhibition: 1700 nM
Beside the measured number, compound 3's estimate is 2.1-fold (0.31 log units) above it, within the range that was stated.
By their numbers in this assay, from the lowest: compounds 1 and 3 (each within the scatter of the next); then compound 2.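

For the compounds shown here, putting methoxy in place of chloro on this aromatic carbon, meta to a large group, gives a 2.2-fold lower number from compound 2 to compound 3 (0.35 log units; beyond the scatter) in this assay, a modest step but one beyond the scatter, so the group held at this place does matter for the number, and the first measured change on a ring with no halogen shows that a halogen is not needed here. The 3-methoxyphenyl ring and the 4-bromophenyl ring of the earlier compound give a 1.1-fold higher number from compound 1 to compound 3 (0.05 log units; within the scatter), within the scatter, so these two compounds cannot be told apart, and among the three rings compared so far the 3-chlorophenyl of compound 2 is the one that stands apart. Nothing available explains why methoxy and chloro differ at this place, and the size of the step alone cannot supply a reason.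

The compounds shown leave open whether the step follows from methoxy itself or would be shared by other groups at the same aromatic carbon, such as a nitrile, a hydroxy group or a dimethylamino group. They also leave open how much the place on the ring counts apart from the group, since the 4-bromophenyl and 3-methoxyphenyl rings differ in both.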